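Chain variation at the aryl ether in an isoflavone-type series

A few compounds are considered here, and "the series" means these few. Any claim that something is new, unique, unknown or untested is made for them only; others in the source may bear on it.

Measured so far:
compound 1 `CCOC(=O)CCCCCOc1ccc2c(=O)c(-c3ccc(O)cc3)coc2c1`, 280 nM
compound 2 `CCOC(=O)COc1ccc2c(=O)c(-c3ccc(O)cc3)coc2c1`, 130 nM
compound 3 `O=c1c(-c2ccc(O)cc2)coc2cc(OCCCCCCCCCO)ccc12`, 700 nM

All three share one core and differ only in the chain on the aromatic ether oxygen. In an assay (Cricetulus griseus) for inhibition of aldehyde dehydrogenase, mitochondrial (Homo sapiens) (on this read-out higher numbers stand for weaker inhibition and lower numbers for stronger inhibition), compound 2 gives 130 nM, compound 1 gives 280 nM, and compound 3 gives 700 nM, the highest of the three numbers. The step of a 2.2-fold lower number from compound 1 to compound 2 (0.33 log units; beyond the scatter) goes with the shorter ethoxycarbonyl chain; the steps of a 2.5-fold higher number from compound 1 to compound 3 (0.40 log units; beyond the scatter) and a 5.4-fold higher number from compound 2 to compound 3 (0.73 log units; beyond the scatter) both go with the longer hydroxy-terminated chain, so the longer chains so far carry the higher numbers.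

Compound 4 `CCCCCCCCCCCCOc1ccc2c(=O)c(-c3ccc(O)cc3)coc2c1` is not yet measured. The change from compound 3 is propyl in place of hydroxy on a saturated chain carbon, nine bonds along the chain from an oxygen on an aromatic ring. Going by the values given here, no measured step removes a hydroxy or adds an unsubstituted alkyl, so the bearing of the earlier steps is indirect: both steps into compound 3 went in the weaker direction as the chain grew. A further step of modest size in the same direction is therefore expected in this assay, a 2.1-fold higher number from compound 3 to compound 4 (0.33 log units; beyond the scatter). Compound 4 is estimated at 1500 nM, with a range from 500 nM to 4500 nM.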

Compound 4, half-maximal inhibitory concentration: > 9000 nM
Compound 4 ended at the assay's limit (the forecaster's own chance of this, stated with the estimate: 10%); middle value at least 6.0-fold (0.77 log units) from the limit.
By their numbers in this assay, from the lowest: compound 2; then compound 1; then compound 3. At a limit, above all of these: compound 4.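

Compound 4 stands at a limit of this assay, and its entry is a limit and not a number: the limit of > 9000 nM in this assay, at which 1 of the 4 values shown sits.
Propyl in place of hydroxy, nine bonds along the chain from an oxygen on an aromatic ring, gives a large step (an at least 12-fold higher number from compound 3 to compound 4 (1.10 log units; beyond the scatter)), and heptyl in place of ethoxycarbonyl, five bonds along the chain from the same oxygen, gives a larger one (an at least 32-fold higher number from compound 1 to compound 4 (1.50 log units; beyond the scatter)). From the compounds shown here alone, all earlier steps at this chain were modest, so this change shows that the end of the chain can weigh far more than the earlier differences suggested, though the full size of both steps stays unknown at the limit.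

The compounds shown leave open how much of the step goes with losing the hydroxy and how much with the added propyl length, which a shorter unsubstituted chain such as hexyl would help separate. Also open, going by these compounds, is how an amine or a carboxylic acid at the chain end would compare with the hydroxy of compound 3.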